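Ester in Place of Nitro on a Carbamate Series

The source may report more compounds than this note shows. Statements on the series, on what has been measured and on what is new or still open speak of the compounds shown alone.

Compound 1 `CCC(COc1cccc(F)c1)OC(=O)NCc1ccccc1`: > 100000 nM
Compound 2 `CCC(COc1cccc(C#N)c1)OC(=O)NCc1ccccc1`: > 100000 nM
Compound 3 `CCC(COc1cccc([N+](=O)[O-])c1)OC(=O)NCc1ccccc1`: > 100000 nM

In an assay for inhibition of zeta-carotene desaturase, chloroplastic/chromoplastic (Capsicum annuum), using a Dixon plot, with a stated time of 8 h (on this read-out lower numbers stand for stronger inhibition and higher numbers for weaker inhibition), compound 3 gives > 100000 nM, which is a limit of the assay and not a number. Compound 1 likewise gives only a limit. Compound 2 also gives only a limit. Every value shown therefore sits at the limit of > 100000 nM in this assay, at which 3 of the 3 values shown sit, so the steps a step that the two limits leave unreadable from compound 1 to compound 2, a step that the two limits leave unreadable from compound 1 to compound 3 and a step that the two limits leave unreadable from compound 2 to compound 3 cannot be read in size or direction. Compound 4 `CCOC(=O)c1cccc(OCC(CC)OC(=O)NCc2ccccc2)c1` differs from compound 3 by ethoxycarbonyl in place of nitro on an aromatic carbon. For the measured compounds named here, no measured step bears on this change, and the three limits give no direction. Compound 4 is expected at 100000 nM, with a range from 30000 nM to 300000 nM. The estimated step of a number no higher from compound 3 to compound 4 (the limit leaves the size open) is expected to stay at the limit.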

Compound 4, half-maximal inhibitory concentration: > 100000 nM
Compound 4 ended at the assay's limit (the forecaster's own chance of this, stated with the estimate: 85%); the middle value sits exactly at the limit.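

For the compounds shown here, compound 4 gives only a limit, as do compound 1, compound 2 and compound 3, so no step among them can be read: the limit of > 100000 nM in this assay, at which 4 of the 4 values shown sit. The compounds shown leave open how these four groups on the aromatic carbon rank against one another, and whether any group there would give a readable value.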